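Amine substituent swap in 5-HT4 agonist series

A few compounds are considered here, and "the series" means these few. Any claim that something is new, unique, unknown or untested is made for them only; others in the source may bear on it.

Measured compounds:
compound 1 `CC(C)c1nc(C(=O)NCC2(O)CCN(CC3CCOCC3)CC2)c2ccccn12`, 34%
compound 2 `CC(C)c1nc(-c2nnc(C3CCN(C4CCC4)CC3)o2)c2ccccn12`, 55%

In a functional assay on CHO cells for agonist activity at 5-hydroxytryptamine receptor 4 (Homo sapiens), read by a luciferase reporter and cAMP accumulation, with a stated time of 4 h (a higher number here means a larger maximal response, a lower number a smaller maximal response), compound 2 gives the higher of the two numbers, with compound 1 lying beyond the scatter below it. Compound 3 `COCCCN1CCC(c2nnc(-c3nc(C(C)C)n4ccccc34)o2)CC1` differs from compound 2 in one place: 3-methoxypropyl in place of cyclobutyl on an amine nitrogen in a ring. Going by the values given here, no measured pair shows the effect of such a change on the maximal response, so the expected step of a number 5 percentage points lower from compound 2 to compound 3 (within the scatter) is small, within the scatter, and without a confident direction. For compound 3 the estimated maximal response is 50%, in the range 30% to 75%.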

Compound 3, largest response reached (Emax), in percent of the reference or control that the assay uses: 67%
For compound 3 the middle estimate is 17 percentage points below the measured one, and the stated range covers the measured number.
By their numbers in this assay, from the lowest: compound 1; then compound 2; then compound 3.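

In this assay the amine nitrogen in the six-membered ring accepts an open chain, and the step is a number 12 percentage points higher from compound 2 to compound 3 (beyond the scatter) with 3-methoxypropyl in place of cyclobutyl. The four-membered ring of cyclobutyl is therefore not needed on this nitrogen for a high maximal response, and the group here can shift that response beyond the scatter. Nothing at hand accounts for the step. As far as these compounds go, whether the chain or its oxygen carries the step stays open: a plain butyl chain on the same nitrogen would separate the two.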